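The compounds below may be only part of what the source reports. "The series", "measured", "known", "first", "only" and "open" are said of these compounds alone.

Values measured in an ADME assay on MRC5 cells (Homo sapiens), read by MTT assay, with a stated time of 72 h; a lower number here means a stronger inhibitor, a higher number a weaker inhibitor:

- Compound 1 `CSc1ncnc2c1c(-c1ccsc1)cn2[C@@H]1O[C@H](CO)[C@@H](O)[C@H]1O`: > 100000 nM
- Compound 2 `Nc1nc(N)c2c(-c3cccs3)cn([C@@H]3O[C@H](CO)[C@@H](O)[C@H]3O)c2n1`: > 100000 nM
- Compound 3 `Cc1nc(N)c2c(-c3cccs3)cn([C@@H]3O[C@H](CO)[C@@H](O)[C@H]3O)c2n1`: > 100000 nM

Each of these entries is a limit of the assay and not a number. Within the data shown here, compound 3 therefore has no exact place on the scale, and the series so far rests on (the limit of > 100000 nM in this assay, at which 3 of the 3 values shown sit).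

Compound 4 `Cc1nc(N)c2c(I)cn([C@@H]3O[C@H](CO)[C@@H](O)[C@H]3O)c2n1` carries iodo in place of thiophen-2-yl on an aromatic carbon of compound 3: iodo in place of thiophen-2-yl on an aromatic carbon. Among the measured compounds shown here, no measured step makes this exchange. For the measured compounds named here, the only step available, a step that the two limits leave unreadable from compound 2 to compound 3, concerns methyl in place of amino and gives no size to carry over. The expectation in this assay is therefore a cautious one: compound 4 may well remain at the limit, and any readable value could only lie on the side of stronger inhibition. The expected change is an at least 1.6-fold lower number from compound 3 to compound 4 (0.22 log units; that floor lies within the scatter). For compound 4 the estimate is 60000 nM, with an expected range from 8000 nM to 100000 nM.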

Compound 4, half-maximal inhibitory concentration: 85800 nM
For compound 4 the middle estimate is 1.4-fold (0.16 log units) below the measured one, within the range that was stated.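

In this assay, compound 4 is the first compound shown to give a number rather than a limit, and exchanging thiophen-2-yl for iodo on this aromatic carbon, two ring bonds from the ring nitrogen, gives an at least 1.1-fold lower number from compound 3 to compound 4 (0.06 log units; that floor lies within the scatter). From the compounds shown here alone, this is only a floor, so the true size of the step remains unknown, and the floor alone does not establish a change beyond the usual scatter. Among these compounds, the value is nevertheless the first reading that is not a limit, while the other compounds remain at the edge of the assay: the limit of > 100000 nM in this assay, at which 3 of the 4 values shown sit.

Going by these compounds, it remains open what a smaller halogen such as chloro or bromo, or a phenyl ring or an amine, would give on this same carbon. On these data alone, it is also open whether iodo would still give a readable value with amino in place of methyl on the shared core.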